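The source may hold more compounds than are shown below. What is called first, only, known or untested is meant among the compounds shown, and "the series" means these compounds.

Three measured compounds share one core and differ only in the group carried on the aromatic ring that bears the trifluoromethyl. Compound 1 `CC(C(=O)NCc1ccc(C(F)(F)F)cc1N1CCN(C2CCCCC2)CC1)c1ccc(NS(C)(=O)=O)c(F)c1` gives 13.8 nM in an assay on CHO cells for antagonist activity at transient receptor potential cation channel subfamily V member 1 (Homo sapiens), read by FLIPR; on this read-out higher numbers stand for weaker inhibition and lower numbers for stronger inhibition. Compound 2 `CC(C(=O)NCc1ccc(C(F)(F)F)cc1N1CCN(c2ccccc2)CC1)c1ccc(NS(C)(=O)=O)c(F)c1` gives 2 nM, and compound 3 `CCCCSc1cc(C(F)(F)F)ccc1CNC(=O)C(C)c1ccc(NS(C)(=O)=O)c(F)c1` gives 1.9 nM. Compound 3 has the lowest number of the three, yet its gap to compound 2 is within the scatter, so the two cannot be told apart; only its gap to compound 1 is real. The measured steps are a 6.9-fold lower number from compound 1 to compound 2 (0.84 log units; beyond the scatter), a 7.3-fold lower number from compound 1 to compound 3 (0.86 log units; beyond the scatter) and a 1.1-fold lower number from compound 2 to compound 3 (0.02 log units; within the scatter).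

Compound 4 `CC(C(=O)NCc1ccc(C(F)(F)F)cc1SCc1ccccc1)c1ccc(NS(C)(=O)=O)c(F)c1` is not yet measured. From compound 3 it changes by phenyl in place of propyl on a saturated chain carbon bound to a sulfur. Among the measured compounds shown here, no measured step alters the butylsulfanyl itself, so none bears on this change directly. The nearest hint is the step from compound 1 to compound 2, where a saturated ring gave way to an aromatic one on the piperazine and the number fell, and the step from compound 2 to compound 3, where a phenyl-bearing group and a plain butyl chain gave numbers within the scatter. A small step, at most a modest lowering, is therefore expected: a 1.3-fold lower number from compound 3 to compound 4 (0.10 log units; within the scatter). The value of compound 4 is estimated at 1.5 nM, between 0.5 nM and 5 nM.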

Compound 4, inhibition constant: 0.5 nM
Estimate against measurement, compound 4: 3.0-fold (0.48 log units) above; low and high end bracket the measured number.
By their numbers in this assay, from the lowest: compound 4; then compounds 3 and 2 (each within the scatter of the next); then compound 1.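

In this assay, the far end of the sulfur-bound chain proves to matter: phenyl in place of propyl on a saturated chain carbon bound to a sulfur gives a 3.8-fold lower number from compound 3 to compound 4 (0.58 log units; beyond the scatter). Among the compounds shown here, none of the earlier compounds altered the butylsulfanyl group, so they never tested this change. Butylsulfanyl could not be told apart from 4-phenylpiperazin-1-yl, but benzylsulfanyl can, with a 4.0-fold lower number from compound 2 to compound 4 (0.60 log units; beyond the scatter) and, against 4-cyclohexylpiperazin-1-yl, a 28-fold lower number from compound 1 to compound 4 (1.44 log units; beyond the scatter), which leaves compound 4 with the lowest number of the four, its steps to all the others lying beyond the scatter. No measurement available here explains why these numbers shift.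

A single swap of propyl for phenyl cannot show whether the gain needs an aromatic ring or would also come with a saturated one, as in cyclohexylmethylsulfanyl, or whether a longer link, as in 2-phenylethylsulfanyl, would do as well. As far as these compounds go, it also remains open how much the sulfur itself contributes, which benzyloxy or benzylamino in its place could test, and whether a chlorine or methoxy group on the new phenyl ring would move the number further.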